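This account rests on a few compounds, and the source may have more. Where it says the series, first, only, none or still open, it means among the compounds named here.

In a functional assay on MCF7 cells (Homo sapiens) for cytotoxicity, read by MTT assay, with a stated time of 24 h (a lower number here means a stronger inhibitor, a higher number a weaker inhibitor), compound 1 `CC1=C([Se]CC(OC(=O)[C@@H](CO)NC(=O)OC(C)(C)C)C(=O)NCCCCCC(=O)OCc2ccccc2)C(=O)c2ccccc2C1=O` gives 5000 nM. Compound 2 `CC1=C(SCCC(=O)OC(C[Se]C2=C(C)C(=O)c3ccccc3C2=O)C(=O)NCCCCCC(=O)OCc2ccccc2)C(=O)c2ccccc2C1=O` gives 10000 nM in this assay, and compound 3 `CC1=C([Se]CC(OC(=O)[C@@H](CSSC(C)(C)C)NC(=O)C(C)(C)C)C(=O)NCCCCCC(=O)OCc2ccccc2)C(=O)c2ccccc2C1=O` gives 8000 nM. Compound 1 shows the smallest of the three numbers, but the gaps to compound 3 and to compound 2 both fall within the scatter, so the three compounds cannot be separated on these data. Compound 4 `CC1=C([Se]CC(OC(=O)CNC(=O)OC(C)(C)C)C(=O)NCCCCCC(=O)OCc2ccccc2)C(=O)c2ccccc2C1=O` has not yet been measured in this assay. It differs from compound 1 in one place: hydrogen in place of hydroxymethyl on a saturated chain carbon bound to an amide-type nitrogen and a carbonyl carbon. For the measured compounds named here, no measured pair shows a change of this kind, so the expectation rests only on the three values, which sit close together. The step from compound 1 to compound 4 is expected to be small, a 1.2-fold higher number from compound 1 to compound 4 (0.08 log units; within the scatter), with no clear direction and not beyond the scatter. Compound 4 is therefore estimated at 6000 nM in this assay, with a range from 2500 nM to 15000 nM.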

Compound 4, half-maximal inhibitory concentration: 4000 nM
The estimate for compound 4 lay 1.5-fold (0.18 log units) above the measured number, within the range that was stated.
By their numbers in this assay, from the lowest: compounds 4, 1, 3 and 2 (each within the scatter of the next, the first and the last beyond it).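

For the compounds shown here, at this position, on a saturated chain carbon bound to an amide-type nitrogen and a carbonyl carbon, the first single-place comparison in this assay puts hydrogen in place of hydroxymethyl and gives a 1.3-fold lower number from compound 1 to compound 4 (0.10 log units; within the scatter). The hydroxymethyl group, with its one hydrogen-bond donor and one hydrogen-bond acceptor, can therefore be replaced by hydrogen without a difference that this assay can separate from the scatter, and compound 1 and compound 4 cannot be told apart. Nothing available here bears on the reason for this reading.

The compounds shown leave open whether an amine, a carboxylic acid or a longer chain on this carbon would also stay within the scatter of compound 1. They also leave open whether the same step would read alike with a group other than tert-butoxycarbonyl on the nitrogen.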